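This account rests on a few compounds, and the source may have more. Where it says the series, first, only, none or still open, it means among the compounds named here.

Measured in a functional assay for inhibition, with Rattus norvegicus as the target; a lower number here means a stronger inhibitor, a higher number a weaker inhibitor:
- Compound 1 `CCOc1c(C(C)O[Si](C)(C)C(C)(C)C)c(OC(C)=O)c2ccccc2c1OC`: 23900 nM
- Compound 2 `CCCc1c(CCC)c(OC(C)=O)c2ccccc2c1OC`: 1430 nM
- Compound 3 `COc1c(-c2ccccc2)c(-c2ccccc2)c(OC(C)=O)c2ccn(C)c12`: "not active" (no number reported)

Compound 3 stands at the bottom of this small set only in a loose sense: in this assay compound 3 is reported as "not active" (no number reported), so it has no number to compare with the others. Compound 4 `COc1cc(-c2ccccc2)c(OC(C)=O)c2ccn(C)c12` has not yet been measured. It keeps the core of compound 3 but carries hydrogen in place of phenyl on an aromatic carbon. With no number for compound 3, the size of this step cannot be stated, and only a direction can be expected, towards a stronger inhibitor that gives a measurable value. That expectation is tentative. It rests on compound 2 at 1430 nM and compound 1 at 23900 nM, which show that measurable values occur among these acetoxy compounds, while a repeat of the inactive result remains possible. For compound 4 the expected value is about 8000 nM, with an estimated range of 1500 nM to 40000 nM.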

Compound 4, half-maximal inhibitory concentration: 3860 nM
Estimate against measurement, compound 4: 2.1-fold (0.32 log units) above; the measured number falls inside the stated range.
By their numbers in this assay, from the lowest: compound 2; then compound 4; then compound 1.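

No step can be read from compound 3 to compound 4, since compound 3 is reported as "not active" in this assay and has no number. Nothing shown here explains the result. The compounds shown leave open how much the phenyl group contributes to inhibition.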